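The source may hold more compounds than are shown below. What is called first, only, known or untested is meant among the compounds shown, and "the series" means these compounds.

Measured compounds:
compound 1, `CCCCN(CC)Cc1c(C(F)(F)F)nc2n(-c3c(C)cc(C)cc3C)c(Cl)cn12`, 78 nM
compound 2, `CCCN(Cc1ccc(Cl)cc1)Cc1c(C(F)(F)F)nc2n(-c3c(C)cc(C)cc3C)c(Cl)cn12`, 28 nM

Two compounds of the series have been run in an assay on cells for displacement of a labelled ligand from corticotropin-releasing factor receptor 1 (Homo sapiens), with a stated time of 100 min; on this read-out higher numbers stand for weaker inhibition and lower numbers for stronger inhibition. Compound 1 gives the higher of the two numbers, 78 nM. Compound 2 carries a propyl and a chlorobenzyl group on its amino nitrogen where compound 1 carries the butyl(ethyl)amino group. Compound 2 gives 28 nM, a lower number beyond the usual scatter. Among the compounds with values here, no single-change step between measured compounds is available.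

Compound 3, `Cc1cc(C)c(-n2c(Cl)cn3c(CN4CCCC4c4ccccc4)c(C(F)(F)F)nc23)c(C)c1`, is not yet measured. It differs from compound 1 as follows: 2-phenylpyrrolidin-1-yl in place of butyl(ethyl)amino on a saturated chain carbon bound to an aromatic carbon. The change introduces an aromatic ring into the amino group, as compound 2 also does relative to compound 1, and compound 2 with 28 nM gives the lower number. The step in this assay from compound 1 is therefore expected to run toward lower numbers, of modest size and possibly within the scatter. Compound 3 is estimated at 35 nM, with a range of 12 nM to 110 nM, meaning an expected step of a 2.2-fold lower number from compound 1 to compound 3 (0.35 log units; beyond the scatter).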

Compound 3, inhibition constant: > 7000 nM
Compound 3: only a limit was reported; the forecaster's own chance of this, stated with the estimate: 3%; middle value at least 200-fold (2.30 log units) away from the limit.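

In this assay, 2-phenylpyrrolidin-1-yl in place of butyl(ethyl)amino on a saturated chain carbon bound to an aromatic carbon gives an at least 89-fold higher number from compound 1 to compound 3 (1.95 log units; beyond the scatter). The value of compound 3, > 7000 nM, is a limit of the assay and not a number: the limit of > 7000 nM in this assay, at which 1 of the 3 values shown sits. Compound 2, at 28 nM, also carries an aromatic ring in its amino group, so the values show that an aromatic ring in this group does not by itself go with a low number, and that this position does not accept every amino group of this kind.

The compounds shown leave open whether the large step goes with the closed five-membered ring or with the phenyl on it. A plain pyrrolidin-1-yl, without the phenyl, would separate these two changes.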